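The source may report more compounds than this note shows. Statements on the series, on what has been measured and on what is new or still open speak of the compounds shown alone.

Compounds measured so far:
- compound 1, `Cc1nn(-c2ncnc3nc[nH]c23)c2c1C(OCc1ccccc1C#N)CC(=O)N2`, 127 nM in a functional assay on HEK293 cells for agonist activity at G-protein coupled receptor 39 (Homo sapiens), read by scintillation proximity assay and inositol phosphate accumulation, with a stated time of 75 min; on this read-out higher numbers stand for an effect only at larger amounts of compound and lower numbers for an effect already at smaller amounts
- compound 2, `Cc1nn(-c2ncnc3nc[nH]c23)c2c1C(NC(=O)c1ccccc1)CC(=O)N2`, 158 nM in this assay

For the measured compounds named here, compound 2 gives the higher of the two numbers in this assay, but its only neighbour is compound 1, and the step of a 1.2-fold higher number from compound 1 to compound 2 (0.09 log units; within the scatter) lies within the scatter, so the two cannot be ordered. Going by the values given here, the one measured step at this position therefore shows that an exchange of the whole side group on the saturated ring carbon, from an ether bearing a nitrile-substituted benzyl to an amide bearing a phenyl, passes without a change beyond the scatter.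

Compound 3, `Cc1nn(-c2ncnc3nc[nH]c23)c2c1C(OCCn1cccn1)CC(=O)N2`, is not yet measured in this assay. Its difference from compound 2: 2-(1H-pyrazol-1-yl)ethoxy in place of benzamido on a saturated ring carbon. Among the compounds with values here, no measured step bears on this exchange directly; the only related step is a 1.2-fold higher number from compound 1 to compound 2 (0.09 log units; within the scatter), which bears on it in that the same position tolerated a change of group without a shift beyond the scatter. Within the data shown here, the expectation for this assay is a step of a 1.6-fold higher number from compound 2 to compound 3 (0.20 log units; within the scatter) of no more than modest size, with the wider range reflecting that the entering group has no measured counterpart. Compound 3 is estimated at 250 nM, within 80 nM to 800 nM.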

Compound 3, half-maximal effective concentration: 2270 nM
For compound 3 the middle estimate is 9.1-fold (0.96 log units) below the measured one; the measured number lies above the stated range.
By their numbers in this assay, from the lowest: compounds 1 and 2 (each within the scatter of the next); then compound 3.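

Tolerance at this saturated ring carbon has a limit: in this assay the exchange of benzamido for 2-(1H-pyrazol-1-yl)ethoxy gives a 14-fold higher number from compound 2 to compound 3 (1.16 log units; beyond the scatter) and so goes well beyond the scatter, unlike the earlier exchange of side groups. Compound 1 and compound 3 both hold an oxygen on the ring carbon, yet (1H-pyrazol-1-yl)methyl in place of 2-cyanophenyl gives an 18-fold higher number from compound 1 to compound 3 (1.25 log units; beyond the scatter) with that oxygen kept, so among these compounds the ether link alone does not set the number, and the large shift goes with the part of the side group beyond the oxygen. The series offers nothing that accounts for this shift.

Still open, going by these compounds, is whether the shift follows the pyrazole ring itself or the chain that carries it, a question that 2-phenylethoxy or a plain benzyloxy group at the same ring carbon would help to separate. Equally open, on these data alone, is whether a pyrazole ring carried on an amide, in the manner of the benzamido group, would behave as compound 2 does or as compound 3 does.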